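A few compounds are considered here, and "the series" means these few. Any claim that something is new, unique, unknown or untested is made for them only; others in the source may bear on it.

Working notes on the series, all read in a functional assay for inhibition, with Homo sapiens as the target (a lower number here means a stronger inhibitor, a higher number a weaker inhibitor), for now. Compound 1 (`COc1ccc(O)c(CNc2ccccc2)c1`) gives 4700 nM in this test. Compound 2 (`COc1ccc(O)c(CCc2ccccc2)c1`) gives 120 nM in the same test. Compound 3 (`Oc1cc2c(cc1CNc1ccccc1)OCCC2`) gives 1700 nM and stands second highest of the three. Its nearest neighbour is compound 1, with a higher number beyond the scatter, and its furthest is compound 2, with a lower number also beyond the scatter.

Compound 4 (`OCc1ccccc1NCc1cc2c(cc1O)CCCO2`) comes from compound 3 through hydroxymethyl in place of hydrogen on an aromatic carbon with the hydroxymethyl on an aromatic carbon, ortho to a large group. Among the measured compounds shown here, no measured pair shows a change of this kind, so the data offer no direct guide to its size. The expectation in this assay is therefore no step beyond the scatter, and it stays anchored on compound 3 at 1700 nM as the closest measured structure. The estimated change, a 1.1-fold lower number from compound 3 to compound 4 (0.05 log units; within the scatter), is expected to be small. For compound 4 the expected value is 1500 nM with an estimated range from 450 nM to 5000 nM.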

Compound 4, half-maximal inhibitory concentration: 21000 nM
Estimate against measurement, compound 4: 14-fold (1.15 log units) below; measured number outside the range, above it.
By their numbers in this assay, from the lowest: compound 2; then compound 3; then compound 1; then compound 4.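

In this assay hydroxymethyl in place of hydrogen on an aromatic carbon, ortho to a large group, brings a 12-fold higher number from compound 3 to compound 4 (1.09 log units; beyond the scatter) for a change of only 2 heavy atoms. Among the compounds shown here, this is the first single-place step, and it shows that this position of the six-membered aromatic ring of carbon only is sensitive to substitution, with a large loss of inhibition on this change. Nothing measured here bears on the reason for the step.

Still open, as far as these compounds go, is whether the loss belongs to hydroxymethyl itself or would follow any group at this place, a question that methyl, methoxy, an amine or a carboxylic acid on the same carbon could address. Also open, from the compounds shown here alone, is whether hydroxymethyl on another carbon of this ring would bring a step of like size.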